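This account rests on a few compounds, and the source may have more. Where it says the series, first, only, none or still open, it means among the compounds named here.

In an ADME assay on Vero cells (Chlorocebus sabaeus) for cytotoxicity, read by MTT assay, with a stated time of 72 h (a higher number here means a weaker inhibitor, a lower number a stronger inhibitor), three compounds have been measured: compound 1 `O=C(NNC(=O)c1ccccc1[N+](=O)[O-])c1ccc(-n2cccc2)cc1` gives 182000 nM, compound 2 `O=C(NNC(=O)c1ccccc1Br)c1ccc(-n2cccc2)cc1` gives 198000 nM, and compound 3 `Brc1ccccc1-c1nnc(-c2ccc(-n3cccc3)cc2)o1` gives 258000 nM.

Compound 2 and compound 1 differ in one place, (nitro in place of bromo on an aromatic carbon), and this change produced a 1.1-fold lower number from compound 2 to compound 1 (0.04 log units; within the scatter). Compound 3 carries a different core from compound 2; how the two cores differ is not broken down here, and their two values lie within the scatter of each other.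

Compound 4 `O=[N+]([O-])c1ccccc1-c1nnc(-c2ccc(-n3cccc3)cc2)o1` stands to compound 3 as compound 1 stands to compound 2: the change is nitro in place of bromo on an aromatic carbon, the same change in the same place. Because the earlier step was a 1.1-fold lower number from compound 2 to compound 1 (0.04 log units; within the scatter), compound 4 is expected to move by about a 1.1-fold lower number from compound 3 to compound 4 (0.03 log units; within the scatter), a step inside the scatter. Compound 4 is therefore estimated at 240000 nM, between 150000 nM and 400000 nM.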

Compound 4, half-maximal inhibitory concentration: 266000 nM
The estimate for compound 4 lay 1.1-fold (0.04 log units) below the measured number; the measured number falls inside the stated range.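

In this assay, putting nitro in place of bromo on an aromatic carbon gave a 1.0-fold higher number from compound 3 to compound 4 (0.01 log units; within the scatter). Set beside the earlier step, the same change reads alike on the two cores: the same change on two cores in this assay, a 1.1-fold lower number (0.04 log units; within the scatter) from compound 2 to compound 1 and a 1.0-fold higher number (0.01 log units; within the scatter) from compound 3 to compound 4, 1.1-fold (0.05 log units) apart, within the scatter of two such steps. This shows that the swap left the number within the scatter on both cores, but it does not show that the change has any measurable effect of its own, and two cores say nothing about how it would behave on a third.

The compounds shown leave open whether another group at the same place, such as an amine or a carboxylic acid, would move the number beyond the scatter. They also leave open whether any such step would match across these two cores.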